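Fluoro in place of cyclopropyl on an aromatic carbon

The source may report more compounds than this note shows. Statements on the series, on what has been measured and on what is new or still open speak of the compounds shown alone.

In a physicochemical assay for lipophilicity, using the shake flask method, in phosphate buffer, measured as octanol-water partition, at pH 7.4 (on this read-out lower numbers stand for lower lipophilicity and higher numbers for higher lipophilicity), compound 1 (`Cc1ncccc1-c1cnc(NCc2c(F)cc(C3CC3)c3c2CCO3)n2cnnc12`) carries the entry "not determined" (no result reported) and so stands at no number. Going by the values given here, compound 2 (`Cc1ncccc1-c1cnc(NCc2c(F)cc(C#N)c3c2CCO3)n2cnnc12`) gives 2.2 in this assay and is the only measured value nearby. Compound 3 (`Cc1ncccc1-c1cnc(NCc2c(F)cc(F)c3c2CCO3)n2cnnc12`) has yet to be measured. The change (fluoro in place of cyclopropyl on an aromatic carbon) is fluoro in place of cyclopropyl on an aromatic carbon. Among the compounds with values here, no measured step guides this change, so only a modest move toward lower numbers in this assay is expected on going from compound 1 to compound 3, and its size remains uncertain. Compound 3 is estimated at 2.5 with an expected range from 2 to 3 in this measurement.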

Compound 3, distribution coefficient: 2.6
For compound 3 the middle estimate is 0.10 log units below the measured one; the range from low to high includes it.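

At this position the groups now have a measured order in this assay: the fluoro of compound 3 reads higher than the cyano of compound 2 (a number 0.40 log units higher from compound 2 to compound 3 (beyond the scatter)), so the position responds to the group it carries. Going by these compounds, the step from compound 1 to compound 3 cannot be read, and how cyclopropyl compares with fluoro stays unknown. Nothing available here accounts for the step. The compounds shown leave open where an amine, a carboxylic acid or a longer carbon chain on this aromatic carbon would fall.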